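This account rests on a few compounds, and the source may have more. Where it says the series, first, only, none or still open, it means among the compounds named here.

Of the compounds shown here, three sharing one core have been measured, differing only in a saturated chain attached to it: compound 1 `CC/C(C)=N\Nc1nc(-c2cccc([N+](=O)[O-])c2)cs1`, compound 2 `CCC/C(C)=N\Nc1nc(-c2cccc([N+](=O)[O-])c2)cs1` and compound 3 `CCCCC/C(CC)=N\Nc1nc(-c2cccc([N+](=O)[O-])c2)cs1`. In a functional assay, with a stated time of 16 h (on this read-out higher numbers stand for weaker inhibition and lower numbers for stronger inhibition), compound 1 gives 1040000 nM, compound 2 gives 1040000 nM and compound 3 gives 1050000 nM. From compound 2 to compound 1 the change hydrogen in place of methyl on a saturated chain carbon, two bonds along the chain from a carbon with a double bond to nitrogen produced no change at the digits printed from compound 2 to compound 1 (within the scatter). The difference between the cores of compound 2 and compound 3 is not broken down here. Compound 4 `CCCC/C(CC)=N\Nc1nc(-c2cccc([N+](=O)[O-])c2)cs1` has not yet been measured; it follows from compound 3 by hydrogen in place of methyl on a saturated chain carbon, four bonds along the chain from a carbon with a double bond to nitrogen, the same kind of change, though the place differs, being four bonds along the chain from the carbon with a double bond to nitrogen rather than two. The step of a 1.0-fold lower number from compound 3 to compound 4 (0.00 log units; within the scatter) is expected to be about as small, because the earlier change gave no change at the digits printed from compound 2 to compound 1 (within the scatter). Compound 4 is estimated at 1040000 nM in this assay.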

Compound 4, half-maximal inhibitory concentration: 1040000 nM
The estimate for compound 4 equals the measured number at the digits printed; low and high end bracket the measured number.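

In this assay, putting hydrogen in place of methyl at the end of the chain gives a 1.0-fold lower number from compound 3 to compound 4 (0.00 log units; within the scatter). Set beside the earlier step, the same change looks alike on the two cores: the same change on two cores in this assay, no change at the digits printed (within the scatter) from compound 2 to compound 1 and a 1.0-fold lower number (0.00 log units; within the scatter) from compound 3 to compound 4, 1.0-fold (0.00 log units) apart, within the scatter of two such steps

So in this small set, the change carries from one core to the other without a visible effect on the number, but two flat steps, at different places on the chain, do not show that it would stay flat on other cores or at other places.

The compounds shown leave open whether a longer chain would move the number. Going by these compounds, it also remains open whether an amine or a carboxylic acid on the chain would do so.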